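Benzylamino in place of arylamino on a shared core

This account rests on a few compounds, and the source may have more. Where it says the series, first, only, none or still open, it means among the compounds named here.

Measured compounds:
compound 1 `Cc1ccc(NC2=CC(=O)c3c(nc4n3[C@H]3OC[C@@H](O)[C@H]3OC4)C2=O)cc1C` — 4320 nM
compound 2 `CCOc1ccccc1NC1=CC(=O)c2nc3n(c2C1=O)[C@H]1OC[C@@H](O)[C@H]1OC3` — 6040 nM

Of the compounds shown here, two built on this core have been measured in a functional assay on HeLa cells (Homo sapiens) for inhibition, read by sulforhodamine B assay; on this read-out higher numbers stand for weaker inhibition and lower numbers for stronger inhibition. Compound 1 gives 4320 nM, the lowest of the two numbers, and compound 2 gives 6040 nM; the gap between them lies within the scatter of repeated measurements, so the two stand level on this read-out, and neither can be called the stronger inhibitor.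

Compound 3 `O=C1C(NCc2ccccc2)=CC(=O)c2c1nc1n2[C@H]2OC[C@@H](O)[C@H]2OC1` differs from compound 1 in one place: benzyl in place of 3,4-dimethylphenyl on an amine nitrogen. Among the compounds with values here, no measured pair shows what this kind of exchange does on this core; both measured compounds carry a substituted phenyl on that amine nitrogen, and compound 3 is the only one with a benzyl there. The expectation therefore rests on the two numbers alone, which sit close together. A modest step toward weaker inhibition is expected, of a size that may not exceed the scatter, a 1.9-fold higher number from compound 1 to compound 3 (0.27 log units; within the scatter). For compound 3 the estimate is 8000 nM, with a range from 2500 nM to 25000 nM.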

Compound 3, half-maximal inhibitory concentration: 11000 nM
The estimate for compound 3 lay 1.4-fold (0.14 log units) below the measured number, within the range that was stated.
By their numbers in this assay, from the lowest: compounds 1, 2 and 3 (each within the scatter of the next, the first and the last beyond it).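

In this assay, within the data shown here, the exchange of (3,4-dimethylphenyl)amino for benzylamino gives the first single change on the shared core that can be read, a 2.5-fold higher number from compound 1 to compound 3 (0.41 log units; beyond the scatter), so the group on this amine nitrogen does bear on the number, if only modestly. The step arises although the group that leaves and the group that enters each hold one six-membered aromatic ring of carbon only, with no hydrogen-bond donors or acceptors and no net charge, and differ by a single heavy atom in the count. Nothing measured here accounts for the step, and it stands as an observation on this one pair.

The pair changes two things at once, the two methyl groups on the ring and the link from the ring to the nitrogen, so an unsubstituted phenyl on the same nitrogen would be needed to tell these apart. From the compounds shown here alone, whether the trend carries further remains open, for instance with a longer chain such as 2-phenylethyl, a benzyl ring bearing methoxy or chlorine, or a simple alkyl group such as cyclohexyl in place of the ring.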